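This account rests on a few compounds, and the source may have more. Where it says the series, first, only, none or still open, it means among the compounds named here.

Measured compounds:
- compound 1, `O=C(CSc1cccc(O)c1)Nc1ccc2nc(NC(=O)c3cc(Cl)cc(Cl)c3)sc2c1`: 1530 nM
- compound 2, `CCn1c(CNc2ccc(OC)cc2)nnc1SCC(=O)Nc1ccc(Cl)cc1`: 63500 nM
- compound 3, `Cc1ccc(S(=O)(=O)Nc2nc(C)c(NC(=O)Nc3ccc(Cl)cc3)s2)cc1`: 88800 nM

In a functional assay on U2OS cells (Homo sapiens) for antiproliferative activity, read by MTT assay, with a stated time of 72 h (a higher number here means a weaker inhibitor, a lower number a stronger inhibitor), compound 1 gives 1530 nM, the lowest number of the three. Compound 2 gives 63500 nM and compound 3 gives 88800 nM; both of these gaps from compound 1 lie well beyond the scatter, so compound 1 is the strongest inhibitor of the three in this assay. Going by the values given here, compound 2 and compound 3 share no core with compound 1, and no step between any two measured compounds differs in a single place, so nothing here shows how a change on the core of compound 1 moves the read-out.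

The next compound, compound 4, `O=C(CSc1cccc(O)c1)Nc1ccc2nc(NC(=O)c3ccc4ccccc4c3)sc2c1`, keeps the core of compound 1 and differs from it in one place: naphthalen-2-yl in place of 3,5-dichlorophenyl on a carbonyl carbon. Nothing in the measured set contains this change. The step of a 1.2-fold higher number from compound 1 to compound 4 (0.07 log units; within the scatter) is therefore expected to stay within the usual scatter, with no firm direction. Compound 4 is estimated at 1800 nM in this assay, and the range 500 nM to 6500 nM is expected to cover the eventual number, with the wide band reflecting the absence of any matched step.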

Compound 4, half-maximal inhibitory concentration: 1770 nM
Compound 4: middle estimate off by 1.0-fold (0.01 log units), on the high side, and the stated range covers the measured number.
By their numbers in this assay, from the lowest: compounds 1 and 4 (each within the scatter of the next); then compounds 2 and 3 (each within the scatter of the next).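

In this assay, the series now has its first step that differs in one place: a 1.2-fold higher number from compound 1 to compound 4 (0.06 log units; within the scatter), with naphthalen-2-yl in place of 3,5-dichlorophenyl on a carbonyl carbon whose other neighbour is an amide-type nitrogen. On this read-out, the two groups cannot be told apart at this position, although the entering group has 10 heavy atoms, all carbon, and 2 six-membered aromatic rings, while the leaving group has 8 heavy atoms, including 2 chlorine, and one such ring. The two chlorine atoms are therefore not required to keep the number within the scatter of compound 1 in this matched pair, though this single step says nothing about why, and no measurement at hand bears on the reason.

The compounds shown leave open how this position would read with an aryl group carrying an amine or a carboxylic acid, or with a saturated group such as cyclohexyl on the same carbonyl carbon. They also leave open whether a change elsewhere on the shared core would move the number beyond the scatter.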